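The compounds below may be only part of what the source reports. "The series", "measured", "known", "first", "only" and "open" are said of these compounds alone.

Compound 1: `CCC(c1ccccc1)c1nc(-c2ccc(Cl)cc2)c(CC(=O)O)s1` — > 100000 nM
Compound 2: `O=C(O)Cc1sc(C(c2ccc(F)cc2)c2ccc(F)cc2)nc1-c1ccnc(F)c1` — 4.7 nM
Compound 3: `O=C(O)Cc1sc(C(c2ccc(F)cc2)c2ccc(F)cc2)nc1-c1ccnc(N2CCC2)c1` — > 100000 nM

All three were tested in an in vitro functional assay on HEK285-7 cells for antagonist activity at prostaglandin D2 receptor 2 (Homo sapiens), read by BRET and beta-arrestin recruitment; a lower number here means a stronger inhibitor, a higher number a weaker inhibitor. Compound 1 gives only a limit of the assay, > 100000 nM, so no number is known for it; it shares this limit with one other compound, as the note the limit of > 100000 nM in this assay, at which 2 of the 3 values shown sit, records. Compound 2, by contrast, gives 4.7 nM. Compound 3 gives only a limit, > 100000 nM. Among the compounds with values here, the one measured step, an at least 21000-fold higher number from compound 2 to compound 3 (4.32 log units; beyond the scatter), concerns a substituent on an aromatic ring.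

The step from compound 1 to compound 4 `O=C(O)Cc1sc(C(Cc2ccccc2)c2ccccc2)nc1-c1ccc(Cl)cc1` is a different kind of change, (phenyl in place of methyl on a saturated chain carbon, two bonds along the chain from two aromatic carbons). No measured step touches this saturated chain carbon, so nothing shown speaks directly to its size. Within the data shown here, compound 2 suggests that two aromatic rings near this carbon are compatible with a strong inhibitor, while compound 1 shows that the smaller chain is not; no measured pair isolates that difference. Compound 4 is therefore expected to give 8000 nM, within 300 nM to 100000 nM, an expected step of an at least 12-fold lower number from compound 1 to compound 4 (1.09 log units; beyond the scatter), with a real chance that only a limit is reported again.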

Compound 4, half-maximal inhibitory concentration: 510 nM
Beside the measured number, compound 4's estimate is 16-fold (1.20 log units) above it; the range from low to high includes it.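

Within the data shown here, at this saturated chain carbon the earlier compounds offered no measured step, and this assay now gives one: phenyl in place of methyl, which can also be read as ethyl to benzyl, brings an at least 190-fold lower number from compound 1 to compound 4 (2.29 log units; beyond the scatter). The position therefore accepts a benzyl group, with its six-membered aromatic ring, in a compound that gives a real number rather than a limit. The true size of the step remains unknown, because compound 1 stands at a limit of the assay and not at a number: the limit of > 100000 nM in this assay, at which 2 of the 4 values shown sit.

On these data alone, what stays open is whether the gain depends on the aromatic ring itself or simply on the added carbon atoms. A cyclohexyl ring or a plain longer chain in place of the phenyl would separate these two readings.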